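Carbonyl substituent change from compound 3 to compound 4

This account rests on a few compounds, and the source may have more. Where it says the series, first, only, none or still open, it means among the compounds named here.

Values in a physicochemical assay for lipophilicity, at pH 7.4; on this read-out lower numbers stand for lower lipophilicity and higher numbers for higher lipophilicity:
- compound 1 `CNC(=O)c1cc(C)n(Cc2cc(Cl)ccc2OCc2ccccc2)n1`: > 3.7, a limit
- compound 2 `Cc1cc(C(=O)Nc2c(F)cccc2F)nn1Cc1cc(Cl)ccc1OCc1ccccc1`: 3.7
- compound 3 `Cc1cc(NC(=O)C(C)C)nn1Cc1cc(Cl)ccc1OCc1ccccc1`: > 3.7, a limit

Compound 3 gives only a limit, > 3.7, and so shares (the limit of > 3.7 in this assay, at which 2 of the 3 values shown sit). In compound 4 `Cc1cc(NC(=O)CC2CCCCC2)nn1Cc1cc(Cl)ccc1OCc1ccccc1`, cyclohexylmethyl stands in place of isopropyl on a carbonyl carbon (cyclohexylmethyl in place of isopropyl on a carbonyl carbon). The measured steps are a number no higher from compound 1 to compound 2 (the limit leaves the size open), a step that the two limits leave unreadable from compound 1 to compound 3 and a number no lower from compound 2 to compound 3 (the limit leaves the size open). None of them changes this group, and none has a readable size, so they give only weak guidance. On the added carbon alone, a rise in this assay is expected, estimated as a step that the limit leaves unreadable from compound 3 to compound 4, and another report as a limit is likely. For compound 4 the estimated value is 4.3, with an expected range of 3.7 to 5.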

Compound 4, distribution coefficient: 3.2
For compound 4 the middle estimate is 1.10 log units above the measured one, and the stated range ends above it.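

For the compounds shown here, at the carbonyl carbon, cyclohexylmethyl in place of isopropyl gives the first readable step at this position in this assay: a number at least 0.50 log units lower from compound 3 to compound 4 (beyond the scatter). Against the two carbamoyl compounds the change at the aromatic carbon reads a number 0.50 log units lower from compound 2 to compound 4 (beyond the scatter), and a number at least 0.50 log units lower from compound 1 to compound 4 (beyond the scatter). The full size of the first and last of these steps stays open because each rests on a limit: the limit of > 3.7 in this assay, at which 2 of the 4 values shown sit.

The compounds shown leave open whether the ring or the chain length carries the step. A straight heptyl chain or a cyclohexyl group on the carbonyl carbon would separate the two.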